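Removing the fluoro from compound 1

This account rests on a few compounds, and the source may have more. Where it says the series, first, only, none or still open, it means among the compounds named here.

Within the data shown here, in a functional assay on CWR22R cells (Homo sapiens) for antiproliferative activity, read by CCK-8 assay, with a stated time of 6 days (on this read-out higher numbers stand for weaker inhibition and lower numbers for stronger inhibition), compound 1 (`CCN(c1ccc(C#N)c(Cl)c1)c1cc(-c2ccc(F)nc2)ccc1C`) gives 16500 nM and compound 2 (`N#Cc1ccc(N2CCc3cc(-c4cnc5ccccc5c4)ccc3C2)cc1C(F)(F)F`) gives 25900 nM as the only other measured number, and these two values lie within the scatter of each other. Compound 1 therefore has no separation from compound 2 on the data so far. Compound 3 (`CCN(c1ccc(C#N)c(Cl)c1)c1cc(-c2cccnc2)ccc1C`) differs from compound 1 in one place (hydrogen in place of fluoro on an aromatic carbon), with hydrogen in place of fluoro on an aromatic carbon, next to the ring nitrogen, so that 6-fluoropyridin-3-yl becomes pyridin-3-yl. Among the measured compounds shown here, no measured pair shows this exchange, so no step beyond the scatter is expected in this assay for it, and no direction can be argued. The expected change is small, an estimated 1.1-fold higher number from compound 1 to compound 3 (0.04 log units; within the scatter) in size. The reference point is compound 1 at 16500 nM as the closest structure. Compound 3 is expected at 18000 nM with an estimated range of 8000 nM to 40000 nM on repeat measurement.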

Compound 3, half-maximal inhibitory concentration: 2000 nM
The estimate for compound 3 lay 9.0-fold (0.95 log units) above the measured number, outside the stated range (below it).
By their numbers in this assay, from the lowest: compound 3; then compounds 1 and 2 (each within the scatter of the next).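

In this assay, among these compounds, the carbon next to the ring nitrogen is the first place where a one-place change moves the read-out beyond the scatter: hydrogen in place of fluoro gives an 8.3-fold lower number from compound 1 to compound 3 (0.92 log units; beyond the scatter). The earlier compounds shown here offered no matched pair, so neither the sensitivity of this position nor the direction of the change could be seen; here, pyridin-3-yl gives stronger inhibition than 6-fluoropyridin-3-yl. No measurement at hand accounts for the step, and its origin remains unassigned.

As far as these compounds go, it remains open whether the step is specific to losing fluoro or whether other groups on this carbon, such as a methoxy or an amine, would also separate from compound 1. This single pair also leaves open whether the exchange gives the same step on a different core.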